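Fluoro for Chloro on the Benzyl Group of Compound 3

A few compounds are considered here, and "the series" means these few. Any claim that something is new, unique, unknown or untested is made for them only; others in the source may bear on it.

Measured compounds in an ADME assay on MT4 cells (Homo sapiens) for cytotoxicity, read by MTT assay, with a stated time of 5 days; on this read-out higher numbers stand for lower toxicity in this test and lower numbers for higher toxicity in this test:
compound 1 `Cc1ccc(Cn2cc(CNC(=O)c3cnc(Nc4ccc(C#N)cc4)cc3Oc3c(C)cc(C)cc3C)nn2)cc1` gives 165000 nM
compound 2 `Cc1cc(C)c(Oc2cc(Nc3ccc(C#N)cc3)ncc2C(=O)NCc2cn(CC(N)=O)nn2)c(C)c1` gives 24000 nM
compound 3 `Cc1cc(C)c(Oc2cc(Nc3ccc(C#N)cc3)ncc2C(=O)NCc2cn(Cc3cccc(Cl)c3)nn2)c(C)c1` gives 187000 nM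

The three compounds share a core and differ only in the group carried on the saturated chain carbon bound to the aromatic nitrogen. In this assay compound 3 gives 187000 nM. The step of a 1.1-fold higher number from compound 1 to compound 3 (0.05 log units; within the scatter) lies within the scatter, whereas the step of a 7.8-fold higher number from compound 2 to compound 3 (0.89 log units; beyond the scatter) lies beyond it, as does a 6.9-fold lower number from compound 1 to compound 2 (0.84 log units; beyond the scatter).

Compound 4 `Cc1cc(C)c(Oc2cc(Nc3ccc(C#N)cc3)ncc2C(=O)NCc2cn(Cc3cccc(F)c3)nn2)c(C)c1` arises from compound 3 by fluoro in place of chloro on an aromatic carbon. Going by the values given here, no measured step exchanges one halogen for another on that ring. The closest comparison is a 1.1-fold higher number from compound 1 to compound 3 (0.05 log units; within the scatter), where a 3-chlorophenyl replaced a 4-methylphenyl with no movement beyond the scatter. The exchange here is smaller than that, so no step beyond the scatter is expected; the expected step of a 1.1-fold lower number from compound 3 to compound 4 (0.03 log units; within the scatter) is essentially flat. Compound 4 is therefore estimated at 175000 nM, with a range from 90000 nM to 340000 nM.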

Compound 4, half-maximal cytotoxic concentration: >= 204000 nM
Compound 4: no number, only a limit (the forecaster's own chance of this, stated with the estimate: 10%); middle value at least 1.1-fold (0.06 log units) away from the limit.
By their numbers in this assay, from the lowest: compound 2; then compounds 1 and 3 (each within the scatter of the next). At a limit, above all of these: compound 4.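

In this assay compound 4 is recorded only as a limit of the assay, not as a number: the limit of >= 204000 nM in this assay, at which 1 of the 4 values shown sits. Going by these compounds alone, this is the first exchange of one halogen for another on this ring, and it reads an at least 1.0-fold higher number from compound 3 to compound 4 (0.03 log units; that floor lies within the scatter), alongside an at least 1.2-fold higher number from compound 1 to compound 4 (0.09 log units; that floor lies within the scatter); neither floor leaves the scatter, so the true size of either gap cannot be told, though fluoro in place of chloro brought no lower number here. The 3-fluorophenyl group also stands well apart from carbamoyl on the same chain carbon, as the 3-chlorophenyl and 4-methylphenyl groups do, with an at least 8.5-fold higher number from compound 2 to compound 4 (0.92 log units; beyond the scatter).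

The compounds shown leave open whether bromo or methoxy in place of fluoro on this ring would give a similar reading. They also leave open whether an amine or a carboxylic acid on the chain carbon would read closer to compound 2.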